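The source may report more compounds than this note shows. Statements on the series, on what has been measured and on what is new or still open speak of the compounds shown alone.

In a functional assay on SW620/5-FU cells (Homo sapiens) for cytotoxicity, read by MTT assay, with a stated time of 48 h, in the presence of a further agent that is not named here (a lower number here means that less compound is needed, a higher number that more compound is needed for the effect), compound 1 (`COc1ccc(-c2cc(NNC(=O)Nc3cc(Cl)nc(Cl)c3)nc3c2cnn3C)cc1`) gives 18500 nM, and compound 2 (`COc1ccc(-c2cc(NNC(=O)Nc3cc(Cl)nc(OC(C)C)c3)nc3c2cnn3C)cc1`) gives 47100 nM. Within the data shown here, compound 2 therefore has the higher of the two numbers, and the only measured step between them is a 2.5-fold higher number from compound 1 to compound 2 (0.41 log units; beyond the scatter), a modest change with isopropoxy in place of chloro on an aromatic carbon. Compound 3 (`COc1ccc(-c2cc(NNC(=O)Nc3cc(Br)nc(Br)c3)nc3c2cnn3C)cc1`) has not yet been measured. It carries 2,6-dibromopyridin-4-yl in place of 2-chloro-6-isopropoxypyridin-4-yl on an amide-type nitrogen. Among the measured compounds shown here, the isopropoxy group leaves in this change, so the measured step bears on it in reverse, while no measured step shows what bromo does in place of chloro. A modest move toward a lower number in this assay is therefore expected, of about the same size as a 2.5-fold higher number from compound 1 to compound 2 (0.41 log units; beyond the scatter), which would put the new compound in the neighbourhood of compound 1 at 18500 nM. For compound 3, the estimated value is 17000 nM, with an expected range from 7000 nM to 40000 nM. This estimate means an expected 2.8-fold lower number from compound 2 to compound 3 (0.44 log units; beyond the scatter).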

Compound 3, half-maximal effective concentration: 54100 nM
Estimate against measurement, compound 3: 3.2-fold (0.50 log units) below, outside the stated range (above it).
By their numbers in this assay, from the lowest: compound 1; then compounds 2 and 3 (each within the scatter of the next).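

In this assay, the new result shows that the 2,6-dichloropyridin-4-yl group of compound 1 is not easily replaced on this amide-type nitrogen: exchanging it for 2,6-dibromopyridin-4-yl gives a 2.9-fold higher number from compound 1 to compound 3 (0.47 log units; beyond the scatter), a step of similar size to the earlier isopropoxy change, a 2.5-fold higher number from compound 1 to compound 2 (0.41 log units; beyond the scatter). Removing the isopropoxy group therefore did not by itself bring the number back towards that of compound 1, since the exchange of 2-chloro-6-isopropoxypyridin-4-yl for 2,6-dibromopyridin-4-yl gives only a 1.1-fold higher number from compound 2 to compound 3 (0.06 log units; within the scatter), so neither compound can be placed ahead of the other. Nothing available here explains why either replacement gives a higher number than compound 1.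

The compounds shown leave open whether any group other than chloro can hold the number of compound 1 at this position, for instance fluoro, methoxy or an amine in place of one chloro. They also leave open whether the small differences seen here would persist if the methoxy group on the shared core were exchanged for a hydroxyl or a longer alkoxy chain.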